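Methyl in place of cyclopentyloxy: an expected step

A few compounds are considered here, and "the series" means these few. Any claim that something is new, unique, unknown or untested is made for them only; others in the source may bear on it.

Compound 1 `O=C(CCl)NC(=O)Nc1ccc(OC2CCCC2)cc1` gives 3100 nM
Compound 2 `O=C(CCl)NC(=O)Nc1ccc(OC2CCCCCC2)cc1` gives 2300 nM

Among the measured compounds shown here, compound 1 lies within the scatter of compound 2 in a functional assay on HT-29 cells (Homo sapiens) for inhibition, read by sulforhodamine B assay, with a stated time of 48 h (a higher number here means a weaker inhibitor of growth, a lower number a stronger inhibitor of growth), and these are the only two measured compounds. Compound 3 `Cc1ccc(NC(=O)NC(=O)CCl)cc1` is unmeasured, and methyl in place of cyclopentyloxy on an aromatic carbon describes how it departs from compound 1, with methyl in place of cyclopentyloxy. For the measured compounds named here, the only measured step of a 1.3-fold lower number from compound 1 to compound 2 (0.13 log units; within the scatter) exchanges one ring on the oxygen for another, so it bears on this change only indirectly. The estimated step of a 3.9-fold higher number from compound 1 to compound 3 (0.59 log units; beyond the scatter) is expected to exceed the scatter and point toward weaker growth inhibition. In this assay compound 3 is expected at 12000 nM with 4000 nM to 40000 nM as the estimated range.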

Compound 3, concentration for 50% growth inhibition: 10000 nM
Estimate against measurement, compound 3: 1.2-fold (0.08 log units) above; the measured number falls inside the stated range.
By their numbers in this assay, from the lowest: compounds 2 and 1 (each within the scatter of the next); then compound 3.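

In this assay, methyl in place of cyclopentyloxy gives a 3.2-fold higher number from compound 1 to compound 3 (0.51 log units; beyond the scatter), a step beyond the scatter, unlike the exchange of one ring for another on the oxygen. The position therefore responds to what it carries, and removing the whole cyclopentyloxy group goes with weaker growth inhibition. Nothing measured here explains this step.

Compound 3 loses the oxygen and the ring together, so the compounds shown do not separate the two. Going by these compounds, how a methoxy group, a longer alkoxy chain or an amine would compare at this place remains open.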